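A few compounds are considered here, and "the series" means these few. Any claim that something is new, unique, unknown or untested is made for them only; others in the source may bear on it.

Measured compounds:
compound 1 `COc1ccc(C(=O)/C=C/c2cc(-c3cc(OC)c(OC)c(OC)c3)n[nH]2)cc1OC` — 1780 nM
compound 2 `COc1cc(-c2cc(/C=C/C(=O)c3ccc(F)c(F)c3)[nH]n2)cc(OC)c1OC` — 5310 nM

The two measured compounds share a core and differ only in the aryl group attached to the carbonyl carbon. Going by the values given here, in a functional assay on SK-MEL-28 cells (Homo sapiens) for inhibition, read by sulforhodamine B assay, with a stated time of 48 h (a lower number here means a stronger inhibitor of growth, a higher number a weaker inhibitor of growth), compound 1 gives 1780 nM, the lowest of the two numbers; compound 2 gives 5310 nM, and the one measured step, a 3.0-fold higher number from compound 1 to compound 2 (0.47 log units; beyond the scatter), shows a modest loss when the 3,4-dimethoxyphenyl is replaced by a 3,4-difluorophenyl.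

Compound 3 `COc1cc(C(=O)/C=C/c2cc(-c3cc(OC)c(OC)c(OC)c3)n[nH]2)cc(OC)c1OC` has not yet been measured. It differs from compound 1 by methoxy in place of hydrogen on an aromatic carbon, the new group sitting ortho to a methoxy group, meta to a large group and meta to a methoxy group. Among the compounds with values here, no measured step adds a methoxy group at this ring; the step from compound 1 to compound 2 concerns the same ring but swaps both methoxy groups for fluorines, so it only shows that this ring is sensitive to modest change. Compound 3 is therefore expected to stay near compound 1, with a step of a 1.4-fold lower number from compound 1 to compound 3 (0.14 log units; within the scatter) in this assay. The estimate for compound 3 is 1300 nM, within a range from 400 nM to 4500 nM.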

Compound 3, concentration for 50% growth inhibition: 1820 nM
Compound 3: middle estimate off by 1.4-fold (0.15 log units), on the low side; the range from low to high includes it.
By their numbers in this assay, from the lowest: compounds 1 and 3 (each within the scatter of the next); then compound 2.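

In this assay, methoxy in place of hydrogen on this aromatic carbon, ortho to a methoxy group, meta to a large group and meta to a methoxy group, gives a 1.0-fold higher number from compound 1 to compound 3 (0.01 log units; within the scatter). Going by these compounds alone, the earlier compounds showed only that this aryl group is not indifferent to every change, with 3,4-difluorophenyl in place of 3,4-dimethoxyphenyl giving a 3.0-fold higher number from compound 1 to compound 2 (0.47 log units; beyond the scatter); the new pair shows that this one free ring carbon can carry a methoxy group while compound 1 and compound 3 stay within the scatter of each other. Nothing measured here accounts for that result.

The compounds shown leave open whether a hydroxyl group, an amine or a carboxylic acid on this same aromatic carbon would also stay within the scatter of compound 1, or whether any of them would shift the number beyond it, as the 3,4-difluorophenyl group of compound 2 does. They also leave open whether a longer chain such as ethoxy would be read the same way at this carbon, and whether a methoxy group here would give a similar result on the 3,4-difluorophenyl ring of compound 2.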